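Adding a Second Chloro to a Weak Antiproliferative Spirooxindole

The source may hold more compounds than are shown below. What is called first, only, known or untested is meant among the compounds shown, and "the series" means these compounds.

The measured compounds:
Compound 1, `N#CC1=C(N)Oc2c(c3nc4ccccc4nc3c3ccccc23)C12C(=O)N(Cc1cnnn1-c1ccc(N)cc1)c1ccccc12`, in a functional assay on HCT-116 cells (Homo sapiens) for antiproliferative activity, read by MTT assay, with a stated time of 48 h (a lower number here means a stronger inhibitor, a higher number a weaker inhibitor), gives 45200 nM.
Compound 2, `N#CC1=C(N)Oc2c(N)cc3nc4ccccc4nc3c2C12C(=O)N(Cc1cnnn1-c1ccccc1Cl)c1ccccc12`, gives only a limit of the assay, > 50000 nM.

Compound 2 stands at the edge of what this assay can report: its value is the limit of > 50000 nM in this assay, at which 1 of the 2 values shown sits, so nothing is known of its potency beyond that boundary. Compound 3, `N#CC1=C(N)Oc2c(N)cc3nc4ccccc4nc3c2C12C(=O)N(Cc1cnnn1-c1ccc(Cl)cc1Cl)c1ccccc12`, differs from compound 2 by a single change: chloro in place of hydrogen on an aromatic carbon.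

Going by the values given here, no measured pair shows what such a change does here, and the two values in hand give no direction to lean on. The step from compound 2 to compound 3 is therefore expected to be a number no higher from compound 2 to compound 3 (the limit leaves the size open), nothing beyond the usual scatter. For compound 3 the expected result in this assay is 50000 nM, within a wide range of 15000 nM to 150000 nM, and a reported limit rather than a number remains quite likely.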

Compound 3, half-maximal inhibitory concentration: > 50000 nM
Compound 3: no number, only a limit; the forecaster's own chance of this, stated with the estimate: 60%; the middle value sits exactly at the limit.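

Going by these compounds alone, compound 2 and compound 3 both give only a limit, not a number, so no step between them can be read: the limit of > 50000 nM in this assay, at which 2 of the 3 values shown sit. Going by these compounds, how strongly either compound acts, and whether going from 2-chlorophenyl to 2,4-dichlorophenyl changes that at all, stays open.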